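From 4-ethylphenyl to 3-fluorophenyl on the sulfur

This account rests on a few compounds, and the source may have more. Where it says the series, first, only, none or still open, it means among the compounds named here.

In a functional assay on HCT-116 cells (Homo sapiens) for inhibition, read by CCK-8 assay, with a stated time of 72 h, tested at 2 uM (a lower number here means less inhibition of growth, a higher number more inhibition of growth at the concentration tested), compound 1 (`COc1ccc(SCc2ccc(/C=C/C(=O)Nc3ccccc3N)cc2)cc1OC`) has a reading of 12.9% and compound 2 (`COc1ccc(SCc2ccc(C(=O)Nc3ccccc3N)cc2)cc1`) one of 73.3% while compound 3 (`CCc1ccc(SCc2ccc(C(=O)Nc3ccccc3N)cc2)cc1`) sits at 40.7% as the second highest of the three numbers. Its gaps to compound 1 and to compound 2 both lie beyond the scatter.

Compound 4 (`Nc1ccccc1NC(=O)c1ccc(CSc2cccc(F)c2)cc1`) is still unmeasured and differs from compound 3 in one place, with 3-fluorophenyl in place of 4-ethylphenyl on a sulfur as the whole change. Within the data shown here, only one measured step touches that group: a number 32.6 percentage points lower from compound 2 to compound 3 (beyond the scatter) for ethyl in place of methoxy on an aromatic carbon, a large move beyond the scatter. Among the measured compounds shown here, compound 1 differs from the others in more than one place and supplies no step. For the measured compounds named here, no measured compound carries fluorine, so the direction rests on a single comparison: the ethyl group of compound 3 goes with the lower number in that pair, against compound 2 at 73.3% in the same read-out. A moderate rise in this assay is therefore expected, with wide uncertainty. Going by the values given here, the expected move is a number 14.3 percentage points higher from compound 3 to compound 4 (beyond the scatter) in this estimate, upward and smaller than the one measured step. For compound 4 the estimate is 55% within an expected range of 33% to 77% on the same read-out.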

Compound 4, percent growth inhibition at one concentration: 5.5%
Compound 4: the middle estimate sits 49.5 percentage points above what was measured; measured number below the stated range.
By their numbers in this assay, from the lowest: compounds 4 and 1 (each within the scatter of the next); then compound 3; then compound 2.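

With the rest of the molecule unchanged, the group on the sulfur now has three readings in this assay, and the new step is a number 35.2 percentage points lower from compound 3 to compound 4 (beyond the scatter). Set against the methoxy compound, the same group gives a number 67.8 percentage points lower from compound 2 to compound 4 (beyond the scatter), so the group on the sulfur spans a wide part of the range in this assay, and replacing 4-ethylphenyl or 4-methoxyphenyl with 3-fluorophenyl lowers the reading each time. Among these compounds, the earlier single step showed only that compound 3 read lower than compound 2; the order 4-methoxyphenyl, then 4-ethylphenyl, then 3-fluorophenyl holds for compound 2, compound 3 and compound 4 only, and no measurement at hand explains it.

The names 3-fluorophenyl and 4-ethylphenyl differ in both the substituent and its number, and the compounds shown do not separate these two changes. From the compounds shown here alone, how an unsubstituted phenyl, or a phenyl carrying an amine or a carboxylic acid, would read on the sulfur remains open.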